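The compounds below may be only part of what the source reports. "The series", "measured", "known", "first", "only" and "open" are said of these compounds alone.

Measured compounds in the series:
compound 1 `CCn1c(=O)c2[nH]c(Cc3ccccc3)nc2n(Cc2ccco2)c1=O`, 162 nM
compound 2 `CCn1c(=O)c2[nH]c(Cc3ccco3)nc2n(Cc2ccco2)c1=O`, 126 nM
compound 3 `CCCn1c(=O)c2c(nc(Cc3ccccc3)n2C)n(Cc2ccco2)c1=O`, 43.7 nM

In an assay on HEK293 cells for displacement of a labelled ligand from adenosine receptor A2b (Homo sapiens) (on this read-out lower numbers stand for stronger inhibition and higher numbers for weaker inhibition), compound 1 gives 162 nM and compound 2 gives 126 nM. The change between them is furan-2-yl in place of phenyl on a saturated chain carbon bound to an aromatic carbon and the step is a 1.3-fold lower number from compound 1 to compound 2 (0.11 log units; within the scatter), so the two numbers are not distinguishable from each other. Compound 3 is built on a different core; the difference between the two cores is not broken down here. In this assay compound 3 gives 43.7 nM, the lowest of the three numbers and beyond the scatter from both compound 1 and compound 2.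

Compound 4 `CCCn1c(=O)c2c(nc(Cc3ccco3)n2C)n(Cc2ccco2)c1=O` has not been measured. It differs from compound 3 by furan-2-yl in place of phenyl on a saturated chain carbon bound to an aromatic carbon, the same change, at the same place, as from compound 1 to compound 2. The step from compound 3 to compound 4 is expected to be a 1.2-fold lower number from compound 3 to compound 4 (0.08 log units; within the scatter), because a 1.3-fold lower number from compound 1 to compound 2 (0.11 log units; within the scatter) was a step within the scatter, and the only open question is whether the other core carries the change the same way. For compound 4 the expected value in this assay is 36 nM, with a likely range from 15 nM to 90 nM.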

Compound 4, inhibition constant: 19.1 nM
Estimate against measurement, compound 4: 1.9-fold (0.28 log units) above; measured number inside the range.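

In this assay the change from phenyl to furan-2-yl on the core of compound 3 reads as a 2.3-fold lower number from compound 3 to compound 4 (0.36 log units; beyond the scatter) and clears the scatter, while the same change on the core of compound 1 reads as a 1.3-fold lower number from compound 1 to compound 2 (0.11 log units; within the scatter) and does not. This split does not show that the core alters the change, and the result is compatible with one step of similar size on both cores, though it does not prove that either. Two pairs support no general rule for other cores, and the gap between the steps gives no ground for calling the change larger on one core than on the other: the same change on two cores in this assay, a 1.3-fold lower number (0.11 log units; within the scatter) from compound 1 to compound 2 and a 2.3-fold lower number (0.36 log units; beyond the scatter) from compound 3 to compound 4, 1.8-fold (0.25 log units) apart, within the scatter of two such steps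

Still open, as far as these compounds go, is whether thiophen-2-yl or pyridin-2-yl in the same place, on a saturated chain carbon bound to an aromatic carbon, would give steps of like size on both cores. Also open, from the compounds shown here alone, is how a longer chain in place of the propyl group of compound 4 would read, and whether an amine or a carboxylic acid on that chain would be tolerated.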